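The source may report more compounds than this note shows. Statements on the series, on what has been measured and on what is new or still open speak of the compounds shown alone.

Measured compounds:

compound 1, `CC(/C=N/Nc1ccc([N+](=O)[O-])cc1)=N\NC(=O)c1ccccc1Nc1ccccc1`: "not determined" (no result reported)
compound 2, `CC(/C=N/Nc1ccc([N+](=O)[O-])cc1)=N\NC(=O)c1ccccc1F`: > 12000 nM

In a functional assay on cells (Splenocyte, Mus musculus, strain BALB/c) for inhibition, read by scintillation counting and thymidine incorporation, with a stated time of 72 h (a lower number here means a stronger inhibitor, a higher number a weaker inhibitor), compound 2 gives > 12000 nM, and this is a limit of the assay rather than a measured number. For compound 1 in this assay the reported result is "not determined" (no result reported), so no number is available for it either. Compound 2 therefore stands at the upper edge of what the assay reports, which is the limit of > 12000 nM in this assay, at which 1 of the 2 values shown sits; there is no second number against which to place it.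

Compound 3, `CC(/C=N/Nc1ccc([N+](=O)[O-])cc1)=N\NC(=O)c1ccccc1C`, differs from compound 2 in one place: methyl in place of fluoro on an aromatic carbon. No step between two measured compounds is available, so the numbers shown give no guide to how large an effect such an exchange has in this assay. The step that the limit leaves unreadable from compound 2 to compound 3 is expected to be small, not beyond the usual scatter in either direction. Compound 3 is therefore estimated at 15000 nM, within a range from 5000 nM to 50000 nM, with a fair chance that the assay again reports only a limit.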

Compound 3, half-maximal inhibitory concentration: 6000 nM
Estimate against measurement, compound 3: 2.5-fold (0.40 log units) above; the range from low to high includes it.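

In this assay compound 3 gives 6000 nM, the only single number among the compounds shown, so this place on the ring now has a real reading to build on. Compound 2 gives > 12000 nM, which is a limit of the assay and not a number. Methyl in place of fluoro comes with an at least 2.0-fold lower number from compound 2 to compound 3 (0.30 log units; that floor lies within the scatter), and the true size of this step stays unknown because only one of its two ends is a number: the limit of > 12000 nM in this assay, at which 1 of the 3 values shown sits.

On these data alone, with a single number in hand, it remains open whether the reading at this place depends on methyl in particular or would hold for other groups. The compounds shown do not tell how an amine, a carboxylic acid or a longer chain such as propyl would read at the same place in this assay.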